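Thioether substituent swap on the shared core

The compounds below may be only part of what the source reports. "The series", "measured", "known", "first", "only" and "open" are said of these compounds alone.

Compound 1 `CCC(C)Sc1nc(N)nc2c1ncn2[C@@H]1O[C@H](CO)[C@@H](O)[C@H]1O` is measured in an assay on isolated protein for binding affinity to Equilibrative nucleoside transporter 1 (Homo sapiens) (on this read-out higher numbers stand for weaker inhibition and lower numbers for stronger inhibition), where compound 1 gives 63100 nM. For the measured compounds named here, the only other measured member of the series is compound 2 `CCCC(C)n1cnc2c(SCc3ccccn3)nc(N)nc21`, which in this assay gives 41700 nM. The two numbers lie within the scatter of one another, so compound 1 cannot be separated from compound 2 on this read-out; both sit at the weak end of what the assay resolves. Compound 3 `Nc1nc(SCc2ccccc2[N+](=O)[O-])c2ncn([C@@H]3O[C@H](CO)[C@@H](O)[C@H]3O)c2n1` has not yet been measured. Relative to compound 1 the change is 2-nitrobenzyl in place of sec-butyl on a sulfur. Going by the values given here, no measured pair isolates this change, so nothing in the data fixes its size or direction. On structural grounds alone the step from compound 1 to compound 3 is expected to be a 13-fold lower number from compound 1 to compound 3 (1.10 log units; beyond the scatter) in this assay, toward stronger inhibition, though with wide uncertainty since compound 1 at 63100 nM and compound 2 at 41700 nM give no calibration for a thioether bearing an aromatic ring on this core. For compound 3 the expected value in this assay is 5000 nM, within a range of 500 nM to 30000 nM.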

Compound 3, half-maximal inhibitory concentration: 4570 nM
Compound 3: middle estimate off by 1.1-fold (0.04 log units), on the high side; the range from low to high includes it.
By their numbers in this assay, from the lowest: compound 3; then compounds 2 and 1 (each within the scatter of the next).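

For the compounds shown here, with the rest of compound 1 held fixed, the substituent on a sulfur whose other neighbour is aromatic carbon clearly matters in this assay: 2-nitrobenzyl in place of sec-butyl gives a 14-fold lower number from compound 1 to compound 3 (1.14 log units; beyond the scatter), the only step the series holds and one that lies well beyond the scatter. The position therefore accepts a larger group carrying a six-membered aromatic ring and hydrogen-bond acceptors, and on this read-out the exchange moves toward stronger inhibition rather than away from it. No measurement at hand bears on the cause of this step.

A single pair cannot divide the step between the aromatic ring and the nitro group, so an unsubstituted benzyl on the same sulfur, or a benzyl carrying a methoxy group or a carboxylic acid in place of the nitro group, would be the informative comparison. Also open, from the compounds shown here alone, is whether a straight hexyl chain on the sulfur would match 2-nitrobenzyl or stay with sec-butyl, and compound 2 differs from compound 3 in more than one place and so cannot settle either question.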